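Three Nitroquinoxalines and a Fourth Awaiting Cytotoxicity Data

This account rests on a few compounds, and the source may have more. Where it says the series, first, only, none or still open, it means among the compounds named here.

Compound 1 `CN(C)CCCNc1nc2cc([N+](=O)[O-])ccc2nc1NCc1ccc(C(F)(F)F)cc1` gives 5.66 ug/mL. Compound 2 `CN(C)CCCNc1nc2cc([N+](=O)[O-])ccc2nc1NCc1ccc(F)cc1` gives 4.28 ug/mL. Compound 3 `CN(C)CCCNc1nc2cc([N+](=O)[O-])ccc2nc1NCc1cc(F)cc(C(F)(F)F)c1` gives 2.67 ug/mL. All three were measured in an ADME assay on HEK293 cells (Homo sapiens) for cytotoxicity, read by MTT assay, with a stated time of 24 h; on this read-out higher numbers stand for weaker inhibition and lower numbers for stronger inhibition.

Compound 2 and compound 1 differ by trifluoromethyl in place of fluoro on an aromatic carbon; the step is a 1.3-fold higher number from compound 2 to compound 1 (0.12 log units; within the scatter). Compound 2 and compound 3 differ by 3-fluoro-5-(trifluoromethyl)phenyl in place of 4-fluorophenyl on a saturated chain carbon bound to a nitrogen on an aromatic ring; the step is a 1.6-fold lower number from compound 2 to compound 3 (0.20 log units; within the scatter). From compound 1 to compound 3 the step is a 2.1-fold lower number from compound 1 to compound 3 (0.33 log units; beyond the scatter).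

Compound 4 `CN(C)CCCNc1nc2cc([N+](=O)[O-])ccc2nc1NCc1cc(C(F)(F)F)cc(C(F)(F)F)c1` is not yet measured in this assay. It differs from compound 3 by trifluoromethyl in place of fluoro on an aromatic carbon. This is the same kind of change as from compound 2 to compound 1, but not the same: there the group sits para to a large group, here it sits meta to a large group and meta to a trifluoromethyl group.

Because a 1.3-fold higher number from compound 2 to compound 1 (0.12 log units; within the scatter) was small, the step for compound 4 is expected to be similar and small, a 1.2-fold higher number from compound 3 to compound 4 (0.09 log units; within the scatter). Compound 4 is therefore estimated at 3.3 ug/mL, with a range from 1.5 ug/mL to 7 ug/mL.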

Compound 4, half-maximal inhibitory concentration: 4.32 ug/mL
Compound 4: the middle estimate sits 1.3-fold (0.12 log units) below what was measured; low and high end bracket the measured number.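

In this assay, putting trifluoromethyl in place of fluoro gives a 1.6-fold higher number from compound 3 to compound 4 (0.21 log units; within the scatter). Set beside the same change on the other core, the two steps agree: the same change on two cores in this assay, a 1.3-fold higher number (0.12 log units; within the scatter) from compound 2 to compound 1 and a 1.6-fold higher number (0.21 log units; within the scatter) from compound 3 to compound 4, 1.2-fold (0.09 log units) apart, within the scatter of two such steps. In these two pairs, then, the change carries from one core to the other without a visible difference, but each step is small enough to be repeat-measurement noise, so this does not show that the change truly moves the number, and two pairs say nothing about how it would behave on any further core.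

The compounds shown leave open how this read-out responds when the aromatic ring carries a group other than fluoro or trifluoromethyl, such as a methoxy group or a nitrile. They also leave open what happens when an amine stands in place of the nitro group on the shared core, or when a longer chain replaces the one that ends in the dimethylamino group.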